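The source may hold more compounds than are shown below. What is called first, only, known or untested is meant among the compounds shown, and "the series" means these compounds.

Measured so far:
- compound 1 `COc1ccc(S(=O)(=O)Nc2ccc(-c3nc4cc(NS(=O)(=O)c5ccc(OC)cc5)ccc4o3)cc2)cc1`: 28000 nM
- compound 2 `COc1ccc(S(=O)(=O)Nc2ccc3oc(-c4ccc(NS(=O)(=O)c5cc(F)ccc5OC)cc4)nc3c2)cc1`: 18000 nM

In a functional assay on DLD-1 cells (Homo sapiens) for cytotoxicity, read by resazurin assay, with a stated time of 48 h (a higher number here means that more compound is needed for the effect, a lower number that less compound is needed), compound 2 gives 18000 nM and compound 1 gives 28000 nM, so the two stand within the scatter of each other. With only these two numbers, neither can be ranked.

Compound 3 `COc1ccc(S(=O)(=O)Nc2ccc3oc(-c4ccc(NC(=O)C5CCN(C(C)=O)CC5)cc4)nc3c2)cc1` is the next step from compound 2. The change is a group of 11 heavy atoms (8 carbon, 1 nitrogen, 2 oxygen; one six-membered non-aromatic ring with 1 hetero atom) in place of a group of 12 heavy atoms (7 carbon, 3 oxygen, 1 fluorine, 1 sulfur; one six-membered aromatic ring of carbon only), on a nitrogen on an aromatic ring; the group that enters is (1-acetylpiperidin-4-yl)carbonyl.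

Among the measured compounds shown here, only one measured step bears on this, and only loosely: a 1.6-fold lower number from compound 1 to compound 2 (0.19 log units; within the scatter), with 5-fluoro-2-methoxyphenyl in place of 4-methoxyphenyl on a sulfonyl sulfur. That step stays within the scatter, but it exchanges one aromatic group for another. For the measured compounds named here, no measured compound carries a non-aromatic ring at this place, so the data give no direction for the new group. No shift beyond the scatter is therefore expected in this assay, though the uncertainty is wide. The expected step is a 1.1-fold higher number from compound 2 to compound 3 (0.05 log units; within the scatter). Compound 3 is estimated at 20000 nM, with an expected range of 6000 nM to 60000 nM.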

Compound 3, half-maximal effective concentration: 15000 nM
Beside the measured number, compound 3's estimate is 1.3-fold (0.12 log units) above it; the range from low to high includes it.
By their numbers in this assay, from the lowest: compounds 3, 2 and 1 (each within the scatter of the next).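

In this assay, (1-acetylpiperidin-4-yl)carbonyl on a nitrogen on an aromatic ring gives a 1.2-fold lower number from compound 2 to compound 3 (0.08 log units; within the scatter) and a 1.9-fold lower number from compound 1 to compound 3 (0.27 log units; within the scatter). Among the compounds shown here, this place therefore now has a first reading for a six-membered non-aromatic ring and a carbonyl in place of the sulfonyl carried there by the two earlier compounds, and neither exchange moves the number beyond the scatter, whereas the earlier step had compared only one aromatic sulfonyl group with another. Among these three compounds, none goes against this flat picture, but the data hold no measurement that would explain it.

As far as these compounds go, it remains open whether any group at this place can move the number beyond the scatter, for example a piperidine with a free ring amine instead of the acetyl, a carboxylic acid or a longer chain. Also open, from the compounds shown here alone, is what the (4-methoxyphenyl)sulfonyl group on the other nitrogen contributes, since all three compounds keep it and the core unchanged.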